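Carboxy in place of cyano: a small expected change

The compounds below may be only part of what the source reports. "The series", "measured", "known", "first", "only" and "open" are said of these compounds alone.

Compound 1 `Cc1n[nH]c(C(=O)O)c1Cc1ccc(C(F)(F)F)cc1` and compound 2 `Cc1n[nH]c(C(=O)O)c1Cc1ccc(C#N)cc1` share one core and differ only in the group on the aromatic carbon. In an assay on isolated protein for inhibition of 2-Hydroxyacid oxidase 2 (Rattus norvegicus), tested at 1 uM (on this read-out higher numbers stand for a stronger effect at the one concentration tested and lower numbers for a weaker effect), compound 1 gives 35%, and compound 2 gives 33%. Compound 2 thus stands at the lower of the two numbers, but the step of a number 2 percentage points lower from compound 1 to compound 2 (within the scatter) lies within the scatter, so the two compounds cannot be told apart on this read-out.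

Compound 3 `Cc1n[nH]c(C(=O)O)c1Cc1ccc(C(=O)O)cc1` is not yet measured. It differs from compound 2 by carboxy in place of cyano on an aromatic carbon. For the measured compounds named here, no measured step exchanges cyano for carboxy, so the only guide is the one step at that aromatic carbon, a number 2 percentage points lower from compound 1 to compound 2 (within the scatter), which left this assay essentially unchanged. Nothing recorded points to a larger effect from the new exchange, so compound 3 is expected to stay near compound 2, with a step of a number 3 percentage points lower from compound 2 to compound 3 (within the scatter) that is estimated to remain within the scatter. Compound 3 is therefore estimated to give 30%, within a range from 10% to 55%.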

Compound 3, a percentage reported as inhibition, at one concentration (the size of the read-out at that concentration, not a potency): 40%
Compound 3: middle estimate off by 10 percentage points, on the low side, and the stated range covers the measured number.
By their numbers in this assay, from the lowest: compounds 2, 1 and 3 (each within the scatter of the next).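

Carboxy in place of cyano, on an aromatic carbon para to a large group, gives a number 7 percentage points higher from compound 2 to compound 3 (within the scatter) in this assay and carboxy in place of trifluoromethyl at that same carbon gives a number 5 percentage points higher from compound 1 to compound 3 (within the scatter) so neither exchange can be told from the ordinary spread of repeated measurements. The earlier pair compared only trifluoromethyl with cyano, whereas carboxy brings a hydrogen-bond donor that cyano lacks, and even this exchange leaves the three compounds indistinguishable on this read-out. No measurement at hand explains why these groups read alike.

The compounds shown leave open whether any group at this position can move the number beyond the scatter, for example an amine, an amide or a longer chain. They also leave open whether compound 1, compound 2 and compound 3 would separate into stronger and weaker effects at concentrations other than the single one tested.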